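The source may hold more compounds than are shown below. What is called first, only, known or untested is meant among the compounds shown, and "the series" means these compounds.

Compound 1 `Nc1scc(CN2CCN(C3CCCCC3)CC2)c1C(=O)c1ccc(Cl)cc1`: in an assay on CHO cells for displacement of a labelled ligand from adenosine receptor A1 (Homo sapiens) (a higher number here means weaker binding, a lower number tighter binding), compound 1 gives 1.9 nM.
Compound 2 `Nc1scc(CN2CCN(c3ccc(C(F)(F)F)cc3)CC2)c1C(=O)c1ccc(Cl)cc1`: in this assay compound 2 gives 1.9 nM.

Compound 2 thus stands level with compound 1 at the digits shown; the step from compound 1 to compound 2 was no change at the digits printed from compound 1 to compound 2 (within the scatter). Compound 3 `Nc1scc(CN2CCN(c3ncccn3)CC2)c1C(=O)c1ccc(Cl)cc1` differs from compound 2 by pyrimidin-2-yl in place of 4-(trifluoromethyl)phenyl on an amine nitrogen in a ring. Among the measured compounds shown here, the only step that bears on this position is the one from compound 1 to compound 2, which showed that a carbocyclic and an aryl substituent are both tolerated at this nitrogen without any shift beyond the scatter. For the measured compounds named here, a heteroaryl group has no precedent here, so some uncertainty remains. Compound 3 is therefore expected to sit close to compound 2 in this assay, with an expected step of a 1.6-fold higher number from compound 2 to compound 3 (0.20 log units; within the scatter). The estimate for compound 3 is 3 nM, with a range from 1 nM to 12 nM.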

Compound 3, dissociation constant: 1.7 nM
The estimate for compound 3 lay 1.8-fold (0.25 log units) above the measured number; the range from low to high includes it.
By their numbers in this assay, from the lowest: compounds 3, 1 and 2 (each within the scatter of the next).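

In this assay, pyrimidin-2-yl is also tolerated on this amine nitrogen, with a 1.1-fold lower number from compound 2 to compound 3 (0.05 log units; within the scatter) and a 1.1-fold lower number from compound 1 to compound 3 (0.05 log units; within the scatter). The assay therefore does not separate cyclohexyl, 4-(trifluoromethyl)phenyl and pyrimidin-2-yl, even though pyrimidin-2-yl adds two ring nitrogens and two hydrogen-bond acceptors and has fewer heavy atoms than 4-(trifluoromethyl)phenyl. Nothing available accounts for this tolerance. As far as these compounds go, whether a group as small as methyl, or a phenyl ring carrying a carboxylic acid, would also stay level with these compounds remains open. So does how these groups behave at other adenosine receptors.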